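The compounds below may be only part of what the source reports. "The series", "measured", "known", "first", "only" and "open" are said of these compounds alone.

Compound 1 `FC(F)(F)c1nc2c(Br)cccc2c(Cl)c1Br` was examined in an assay for inhibition of ectonucleoside triphosphate diphosphohydrolase 1 (Homo sapiens), read by malachite green, with a stated time of 10 min; on this read-out lower numbers stand for stronger inhibition and higher numbers for weaker inhibition. In this assay compound 1 gives > 300000 nM, which is a limit of the assay rather than a number. Compound 2 `COc1ccc(-c2cccc3c(Cl)c(Br)c(C(F)(F)F)nc23)cc1` carries a 4-methoxyphenyl in place of bromo on an aromatic carbon. In this assay compound 2 gives > 300000 nM, again a limit and not a number. The step that the two limits leave unreadable from compound 1 to compound 2 consequently cannot be read. Compound 2 thus stands at the limit of > 300000 nM in this assay, at which 2 of the 2 values shown sit. Compound 3 `FC(F)(F)c1ccc(-c2cccc3c(Cl)c(Br)c(C(F)(F)F)nc23)cc1` differs from compound 2 by trifluoromethyl in place of methoxy on an aromatic carbon. Among the compounds with values here, the single measured step bears on compound 3 only in that neither of its ends yielded a number, so no direction beyond the scatter can be foreseen, and the step from compound 2 to compound 3 in this assay is expected to be about a step that the limit leaves unreadable from compound 2 to compound 3. Compound 3 is accordingly estimated at 400000 nM, within 100000 nM to 2000000 nM, most probably once more only a limit.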

Compound 3, half-maximal inhibitory concentration: > 300000 nM
Compound 3 gave a limit, no number; the forecaster's own chance of this, stated with the estimate: 85%; the middle value is on the limit's open side.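

Within the data shown here, compound 2 and compound 3 both give a limit rather than a number in this assay, so no step between them can be read: the limit of > 300000 nM in this assay, at which 3 of the 3 values shown sit. The compounds shown leave open how strongly any of the three inhibits, and which change to the shared core would give a readable number.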